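Swapping a Ring Hydroxy for Methyl in an Aryl Ketone Series

The source may report more compounds than this note shows. Statements on the series, on what has been measured and on what is new or still open speak of the compounds shown alone.

The series is followed in an assay on HEK293 cells for positive allosteric modulation of metabotropic glutamate receptor 3 (Rattus norvegicus), read by thallium flux, with a stated time of 2.5 min; on this read-out lower numbers stand for an effect already at smaller amounts and higher numbers for an effect only at larger amounts of compound. Compound 1 `Cc1c(OCCCCOc2ccccc2C(=O)O)ccc(C(=O)CC2CCCC2)c1C` has an outcome recorded as "not determined" (no result reported), and compound 2 `Cc1c(OCCCCOc2ccc(C(=O)O)c(Cl)c2)ccc(C(=O)CC(C)C)c1C` likewise stands at "not determined" (no result reported). Among the measured compounds shown here, compound 3 `Cc1c(OCCCCOc2ccc(C(=O)O)c(Cl)c2)ccc(C(=O)CC2CCCC2)c1O` is therefore the only member with a number, giving 2250 nM in this assay, so no step between measured compounds can be drawn. Compound 4 `Cc1c(OCCCCOc2ccc(C(=O)O)c(Cl)c2)ccc(C(=O)CC2CCCC2)c1C` differs from compound 3 by one change, (methyl in place of hydroxy on an aromatic carbon), a methyl in place of hydroxy on an aromatic carbon. With nothing measured to guide the direction, the step from compound 3 to compound 4 is expected to be modest, near the scatter, as a 1.5-fold lower number from compound 3 to compound 4 (0.18 log units; within the scatter). Compound 4 is accordingly estimated at 1500 nM, within a range from 400 nM to 6000 nM.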

Compound 4, half-maximal effective concentration: > 10000 nM
Compound 4 ended at the assay's limit; the forecaster's own chance of this, stated with the estimate: 15%; middle value at least 6.6-fold (0.82 log units) from the limit.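

Placing methyl where hydroxy stood, on the aromatic carbon ortho to a (cyclopentylmethyl)carbonyl group, gives an at least 4.4-fold higher number from compound 3 to compound 4 (0.64 log units; beyond the scatter), the first readable step in the series and evidence that this position responds to a single-atom change. For compound 4, > 10000 nM is a limit of the assay and not a number. The step is therefore only a lower bound, and its true size stays unknown: the limit of > 10000 nM in this assay, at which 1 of the 4 values shown sits.

The compounds shown leave open how a methoxy group, an amine or a fluorine on this carbon would read. They also leave open whether hydroxy would count as much with a longer chain on the carbonyl.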